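A few compounds are considered here, and "the series" means these few. Any claim that something is new, unique, unknown or untested is made for them only; others in the source may bear on it.

Measured so far:
- compound 1, `COC(=O)c1coc(-c2coc([C@@H](NC(=O)OC(C)(C)C)[C@@H](C)OC(C)(C)C)n2)n1`: in a functional assay on HCT-116 cells (Homo sapiens) for inhibition, read by CCK-8 assay, with a stated time of 72 h (on this read-out higher numbers stand for weaker inhibition and lower numbers for stronger inhibition), compound 1 gives only a limit, > 100000 nM, not a number.
- compound 2, `COC(=O)c1csc(-c2csc([C@@H](NC(=O)OC(C)(C)C)[C@@H](C)OC(C)(C)C)n2)n1`: in this assay compound 2 gives 19400 nM.

Among the measured compounds shown here, compound 2 therefore holds the only proper number among the two measured compounds; the other entry is the limit of > 100000 nM in this assay, at which 1 of the 2 values shown sits, so nothing can be said about the size of any gap between them. For the measured compounds named here, compound 2 itself is a weak inhibitor, and no step between measured compounds that differ in one place is available to show how a single change shifts the read-out.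

The next compound, compound 3 `CCOC(=O)c1csc(-c2csc(-c3csc([C@@H](NC(=O)OC(C)(C)C)[C@@H](C)OC(C)(C)C)n3)n2)n1`, differs from compound 2 in one place: 4-(ethoxycarbonyl)-1,3-thiazol-2-yl in place of methoxycarbonyl on an aromatic carbon. The change is an extension of the chain of five-membered rings by one further ring carrying the ester, rather than a swap of small groups. Going by the values given here, with no measured step of this kind to lean on, the expectation rests only on the weak value of compound 2.

Compound 3 is expected to move somewhat toward stronger inhibition, an estimated step of a 2.4-fold lower number from compound 2 to compound 3 (0.38 log units; beyond the scatter). Compound 3 is estimated at 8000 nM, with a range from 1500 nM to 40000 nM.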

Compound 3, half-maximal inhibitory concentration: 26500 nM
Compound 3: middle estimate off by 3.3-fold (0.52 log units), on the low side; measured number inside the range.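

In this assay, putting 4-(ethoxycarbonyl)-1,3-thiazol-2-yl in place of methoxycarbonyl on this aromatic carbon, next to the ring nitrogen, gives a 1.4-fold higher number from compound 2 to compound 3 (0.14 log units; within the scatter). Among the compounds shown here, this is the first step between measured compounds that differ in one place, and it shows that a group of 10 heavy atoms, including a whole extra five-membered aromatic ring, can replace a group of 4 heavy atoms with no change in the read-out beyond the usual scatter. The series therefore gains no stronger inhibitor from this longer chain of rings, and the only other entry is a limit rather than a number, so it offers no further size of step to compare: the limit of > 100000 nM in this assay, at which 1 of the 3 values shown sits.

The step also joins two changes, the added ring and an ethyl ester in place of a methyl ester, and the compounds shown cannot separate the two. Going by these compounds, whether a carboxylic acid or a primary amide in place of the ester at this position would move the read-out remains open.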